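The source may report more compounds than this note shows. Statements on the series, on what has been measured and on what is new or still open speak of the compounds shown alone.

Measured so far in a functional assay on SK-BR-3 cells (Homo sapiens) for antiproliferative activity, read by MTT assay, with a stated time of 72 h; a lower number here means a stronger inhibitor, a higher number a weaker inhibitor: compound 1 `CCN(CC)CCNc1cc(C)c2cc(NC(=O)c3ccc(Cl)c(Cl)c3)ccc2n1` gives 3710 nM; compound 2 `CCN1CCN(c2cc(C)c3cc(NC(=O)c4ccccc4C)ccc3n2)CC1` gives 29200 nM; compound 3 `Cc1cc(NCCN2CCN(C)CC2)nc2ccc(NC(=O)c3ccc(Cl)c(Cl)c3)cc12` gives 2690 nM.

Compound 2 stands highest of the three numbers, that is, it is the weakest inhibitor shown. Its nearest neighbour is compound 1 and its furthest is compound 3, and both gaps lie beyond the scatter, so compound 2 is clearly set apart from the other two.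

Compound 4 `CCN1CCN(c2cc(C)c3cc(NC(=O)c4ccc(OC)cc4)ccc3n2)CC1` is compound 2 with one change: 4-methoxyphenyl in place of 2-methylphenyl on a carbonyl carbon. The only measured step among these compounds, a 1.4-fold lower number from compound 1 to compound 3 (0.14 log units; within the scatter), concerns the amine end of the molecule and lies within the scatter; it says nothing about the group on the carbonyl carbon. Compounds 1 and 3 differ from compound 2 in more than one place, so their lower numbers cannot be traced to the carbonyl-bound group alone. Among the measured compounds shown here, no measured step therefore bears on this change, and no direction can be expected beyond the scatter.

On that basis compound 4 is expected to stay close to compound 2, with the step of a 1.3-fold lower number from compound 2 to compound 4 (0.12 log units; within the scatter) expected to fall within the usual variation. Compound 4 is estimated at 22000 nM, expected to lie between 6000 nM and 80000 nM.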

Compound 4, half-maximal inhibitory concentration: 9000 nM
Compound 4: the middle estimate sits 2.4-fold (0.39 log units) above what was measured; measured number inside the range.
By their numbers in this assay, from the lowest: compounds 3 and 1 (each within the scatter of the next); then compound 4; then compound 2.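

In this assay, the group on the carbonyl carbon makes a measurable difference: with the rest of the molecule unchanged, placing 4-methoxyphenyl where 2-methylphenyl stood gives a 3.2-fold lower number from compound 2 to compound 4 (0.51 log units; beyond the scatter) and so a stronger inhibitor, though the step is modest. Among the compounds shown here, the earlier compounds could not show this, as their only step concerned the amine end of the molecule and stayed within the scatter. Nothing measured here explains why the number moves in this direction.

This single swap removes one group and brings in another, so it cannot tell whether the lower number comes from gaining the 4-methoxyphenyl or from losing the 2-methylphenyl; an unsubstituted phenyl, a 4-methylphenyl or a 2-methoxyphenyl on the same carbonyl carbon would help to separate these possibilities. Going by these compounds, it also remains open whether the same swap would lower the number to a similar extent with a different amine end on the shared core, such as the diethylamino chain of compound 1.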